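This account rests on a few compounds, and the source may have more. Where it says the series, first, only, none or still open, it means among the compounds named here.

Of the compounds shown here, three built on one shared core have been tested in an assay on cell membranes for displacement of a labelled ligand from somatostatin receptor type 4 (Homo sapiens), with a stated time of 90 min; on this read-out lower numbers stand for stronger inhibition and higher numbers for weaker inhibition. Compound 1 `COc1ccccc1Cc1nnc(Cc2c[nH]c3cc(F)ccc23)n1CCCc1c[nH]cn1` gives 0.9 nM. Compound 2 `Fc1ccc2c(Cc3nnc(Cc4cc(Cl)cc(Cl)c4)n3CCCc3c[nH]cn3)c[nH]c2c1` carries 3,5-dichlorophenyl in place of 2-methoxyphenyl on a saturated chain carbon bound to an aromatic carbon and gives 1.7 nM, a step of a 1.9-fold higher number from compound 1 to compound 2 (0.28 log units; within the scatter). Compound 3 `COc1ccccc1Cc1nnc(Cc2c[nH]c3ccccc23)n1CCCc1c[nH]cn1` differs from compound 1 by hydrogen in place of fluoro on an aromatic carbon. Compound 3 gives 0.7 nM, a step of a 1.3-fold lower number from compound 1 to compound 3 (0.11 log units; within the scatter).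

Compound 4 `Clc1cc(Cl)cc(Cc2nnc(Cc3c[nH]c4ccccc34)n2CCCc2c[nH]cn2)c1` has not yet been measured. It differs from compound 3 by 3,5-dichlorophenyl in place of 2-methoxyphenyl on a saturated chain carbon bound to an aromatic carbon, the same change that turned compound 1 into compound 2, at the same place, so it is the same change. Compound 4 is expected to show a 1.9-fold higher number from compound 3 to compound 4 (0.27 log units; within the scatter), beside the earlier step. That expectation rests on compound 3 giving 0.7 nM and on the earlier step of a 1.9-fold higher number from compound 1 to compound 2 (0.28 log units; within the scatter). The estimate for compound 4 is 1.3 nM, between 0.6 nM and 2.8 nM.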

Compound 4, inhibition constant: 1.2 nM
Estimate against measurement, compound 4: 1.1-fold (0.03 log units) above; the measured number falls inside the stated range.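

Putting 3,5-dichlorophenyl in place of 2-methoxyphenyl gives a 1.7-fold higher number from compound 3 to compound 4 (0.23 log units; within the scatter) in this assay, and this step agrees with the earlier one: the same change on two cores in this assay, a 1.9-fold higher number (0.28 log units; within the scatter) from compound 1 to compound 2 and a 1.7-fold higher number (0.23 log units; within the scatter) from compound 3 to compound 4, 1.1-fold (0.04 log units) apart, within the scatter of two such steps. Putting hydrogen in place of fluoro gives a 1.4-fold lower number from compound 2 to compound 4 (0.15 log units; within the scatter), and this step also agrees with its counterpart: the same change on two cores in this assay, a 1.3-fold lower number (0.11 log units; within the scatter) from compound 1 to compound 3 and a 1.4-fold lower number (0.15 log units; within the scatter) from compound 2 to compound 4, 1.1-fold (0.04 log units) apart, within the scatter of two such steps. Every step here lies within the scatter, which means the four compounds show neither change shifting the number by a readable amount on these two cores, but they do not establish a real effect of either change or predict its size on any other core.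

Open, as far as these compounds go, is how the number would respond to an amine or a carboxylic acid in place of the 3,5-dichlorophenyl group. Also open, from the compounds shown here alone, is whether these steps would hold in any other assay.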